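Swapping chloro for trifluoromethyl on the urea aryl group

The source may report more compounds than this note shows. Statements on the series, on what has been measured and on what is new or still open speak of the compounds shown alone.

The compounds share one core, varied at the amide or urea end. Compound 1 `O=C(Nc1cccc(-n2cc(-c3ccncc3)c(-c3ccc(Cl)c(O)c3)n2)c1)Nc1ccc(Cl)c(Cl)c1` carries a 3,4-dichlorophenyl urea; in a functional assay on HCC 2998 cells (Homo sapiens) for inhibition, read by sulforhodamine B assay, with a stated time of 48 h (a higher number here means a weaker inhibitor of growth, a lower number a stronger inhibitor of growth), compound 1 gives 13900 nM. Compound 3 `O=C(Nc1cccc(-n2cc(-c3ccncc3)c(-c3ccc(Cl)c(O)c3)n2)c1)Nc1cc(C(F)(F)F)cc(C(F)(F)F)c1` carries two trifluoromethyl groups on that ring, and in this assay compound 3 gives 2410 nM, a lower number than compound 1 by a margin beyond the scatter. Compound 2 `COc1cc(-c2nn(-c3cccc(NC(=O)c4ccc(Cl)c(C(F)(F)F)c4)c3)cc2-c2ccncc2)ccc1Cl` is an amide with a methoxy on the core; in this assay compound 2 reaches only a limit, > 32500 nM (the limit of > 32500 nM in this assay, at which 1 of the 3 values shown sits). Of the two numbers actually read, compound 1 therefore gives the higher one.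

Compound 4 `O=C(Nc1cccc(-n2cc(-c3ccncc3)c(-c3ccc(Cl)c(O)c3)n2)c1)Nc1ccc(Cl)c(C(F)(F)F)c1` differs from compound 1 in a single place: trifluoromethyl in place of chloro on an aromatic carbon. The result reads 3,4-dichlorophenyl to 4-chloro-3-(trifluoromethyl)phenyl. Since compound 3, with trifluoromethyl groups on the same ring, gives 2410 nM, the step from compound 1 is expected to run toward a lower number, a 2.5-fold lower number from compound 1 to compound 4 (0.40 log units; beyond the scatter), though smaller than the gap to compound 3. Compound 4 is thus estimated at 5500 nM in this assay, within 2000 nM to 15000 nM.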

Compound 4, concentration for total growth inhibition: 4120 nM
Compound 4: middle estimate off by 1.3-fold (0.13 log units), on the high side; the range from low to high includes it.
By their numbers in this assay, from the lowest: compounds 3 and 4 (each within the scatter of the next); then compound 1. At a limit, above all of these: compound 2.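

In this assay, trifluoromethyl in place of chloro on the urea aryl ring gives a 3.4-fold lower number from compound 1 to compound 4 (0.53 log units; beyond the scatter). Within the data shown here, the earlier compounds differed from one another in more than one place, so this is the first step here that isolates one change: a single replacement on an aromatic carbon, ortho to a chloro group and meta to a large group, is enough to carry the number beyond the scatter, though the step remains modest. Nothing given here accounts for this step.

What the compounds leave open is whether the lower number is specific to trifluoromethyl, or whether a nitrile, a methyl or a carboxylic acid on the same carbon would move it the same way. From the compounds shown here alone, it also remains open whether this step would keep its size on a core lacking the hydroxyl group.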